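Replacing a methylphenyl amide with a biphenyl amide

The compounds below may be only part of what the source reports. "The series", "measured", "known", "first", "only" and "open" are said of these compounds alone.

Measured so far, in a functional assay on HeLa cells (Homo sapiens) for antiproliferative activity, read by CCK-8 assay, with a stated time of 72 h; a lower number here means a stronger inhibitor, a higher number a weaker inhibitor:
Compound 1 `O=C(Nc1cccc(-c2oc3cc(-c4ccc(F)cc4)ccc3c(=O)c2O)c1)c1ccc(F)cc1F` gives 10700 nM.
Compound 2 `Cc1ccccc1C(=O)Nc1cccc(-c2oc3cc(-c4ccc(F)cc4)ccc3c(=O)c2O)c1` gives 11900 nM.
Compound 3 `O=C(Nc1cccc(-c2oc3cc(-c4ccc(F)cc4)ccc3c(=O)c2O)c1)c1cccc(F)c1` gives 8780 nM.

The three share one core and differ only in the aryl group attached to the amide carbonyl. Compound 2 has the highest of the three numbers, but its steps to the others, a 1.4-fold lower number from compound 2 to compound 3 (0.13 log units; within the scatter) and a 1.1-fold higher number from compound 1 to compound 2 (0.05 log units; within the scatter), both lie within the scatter, so the three are indistinguishable on these data. Compound 4 `O=C(Nc1cccc(-c2oc3cc(-c4ccc(F)cc4)ccc3c(=O)c2O)c1)c1ccc(-c2ccccc2)cc1` carries a different aryl group at the same position: 4-phenylphenyl in place of 2-methylphenyl on a carbonyl carbon. Within the data shown here, no measured step tests an added phenyl ring; the steps that bear on this position, a 1.2-fold lower number from compound 1 to compound 3 (0.09 log units; within the scatter), a 1.4-fold lower number from compound 2 to compound 3 (0.13 log units; within the scatter) and a 1.1-fold higher number from compound 1 to compound 2 (0.05 log units; within the scatter), were all small, showing that swapping one small aryl group for another left this assay unchanged. As far as these compounds go, the larger aryl group in compound 4 is untested, so the expectation rests on that indifference, with widened uncertainty. The expected step is a 1.2-fold lower number from compound 2 to compound 4 (0.08 log units; within the scatter). Compound 4 is estimated at 10000 nM, within a range from 3500 nM to 30000 nM.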

Compound 4, half-maximal inhibitory concentration: > 100000 nM
Compound 4: a limit, no number (the forecaster's own chance of this, stated with the estimate: 10%); middle value at least 10-fold (1.00 log units) from the limit.
By their numbers in this assay, from the lowest: compounds 3, 1 and 2 (each within the scatter of the next). At a limit, above all of these: compound 4.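

In this assay compound 4 gives > 100000 nM, which is a limit of the assay and not a number. The position that showed no response among the smaller aryl groups does respond to this change, which gives an at least 8.4-fold higher number from compound 2 to compound 4 (0.92 log units; beyond the scatter), an at least 9.3-fold higher number from compound 1 to compound 4 (0.97 log units; beyond the scatter) and an at least 11-fold higher number from compound 3 to compound 4 (1.05 log units; beyond the scatter). The tolerance seen with one-ring aryl groups therefore does not extend to 4-phenylphenyl, which brings 2 six-membered aromatic rings where 2-methylphenyl brings one.

With a single large group tested, the compounds shown cannot separate the effect of the second ring from that of its placement on the first. As far as these compounds go, it also stays open whether a phenyl ring carrying an amine or a carboxylic acid, or a cyclohexyl group, on the carbonyl carbon would behave like compound 2 or like compound 4.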